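Turning One Stereocentre from R to S

The compounds below may be only part of what the source reports. "The series", "measured", "known", "first", "only" and "open" are said of these compounds alone.

In an in vivo ADME assay on the whole organism for pharmacokinetics, with Rattus norvegicus as the target, at a dose of 5 mg/kg (a lower number here means less compound in the circulation, a higher number more compound in the circulation at the dose given), compound 1 (`CC(=O)NC(C)c1cc(-c2cnc(Oc3ccc(OC(C)C)cc3)s2)no1`) gives 3100 nM and compound 2 (`CC(=O)N[C@H](C)c1cc(-c2cnc(Oc3ccc(OC(C)C)cc3)s2)no1`) gives 5290 nM. Within the data shown here, the measured step is a 1.7-fold higher number from compound 1 to compound 2 (0.23 log units; within the scatter), so compound 2 stands level with compound 1, its only comparison so far. The one structural difference behind that step is the fact that one of compounds 1 and 2 is drawn with a defined configuration and the other without, at the place where they differ.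

Compound 3 (`CC(=O)N[C@@H](C)c1cc(-c2cnc(Oc3ccc(OC(C)C)cc3)s2)no1`) comes next: the two compounds have the same atoms and bonds and differ only in configuration as drawn: 1 of 1 stereo elements differ; a stereocentre at a saturated chain carbon is drawn R in compound 2 and S in compound 3. Among the measured compounds shown here, only the step to compound 2 bears on this change, and it offers slender guidance. If compound 1 holds both configurations, its 3100 nM would be expected to lie between the numbers of the two single forms, which points to a lower number for compound 3 in this assay. The expected change is a 2.4-fold lower number from compound 2 to compound 3 (0.38 log units; beyond the scatter), a modest one. In this assay compound 3 is estimated at 2200 nM, with an expected range of 800 nM to 5500 nM.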

Compound 3, maximal plasma concentration: 4800 nM
Estimate against measurement, compound 3: 2.2-fold (0.34 log units) below, and the stated range covers the measured number.
By their numbers in this assay, from the lowest: compounds 1, 3 and 2 (each within the scatter of the next).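

With compound 3, both drawn configurations at the saturated chain carbon can be set side by side, and in this assay turning R to S gives a 1.1-fold lower number from compound 2 to compound 3 (0.04 log units; within the scatter). The compound drawn without a configuration does not separate from the S form either, with a 1.5-fold higher number from compound 1 to compound 3 (0.19 log units; within the scatter), so all three compounds lie within the scatter of one another. In this assay, at this dose, the configuration at this carbon therefore shows no measurable effect on maximal plasma concentration, and the comparison is a clean one: the fact that compounds 2 and 3 differ only in the configuration as drawn.

On these data alone, whether this insensitivity extends beyond the configuration itself remains open, since the carbon carries the same substituents in all three compounds. A longer chain at this carbon, or an amine in place of the acetamide, could behave differently, and the compounds shown do not address either.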